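A few compounds are considered here, and "the series" means these few. Any claim that something is new, unique, unknown or untested is made for them only; others in the source may bear on it.

Working notes on the series.

Compound 1 `C=C(Br)C(=O)Nc1ccc(/C=C/C(=O)c2ccccc2)cc1` gives 4000 nM in an ADME assay on CCRF-CEM cells (Homo sapiens) for antiproliferative activity, with a stated time of 48 h; a higher number here means a weaker inhibitor, a lower number a stronger inhibitor. Compound 2 `C=C(Br)C(=O)Nc1ccc(/C=C/C(=O)c2cccc(OC)c2)cc1` gives 2300 nM in this assay; the change made from compound 1 to compound 2 is methoxy in place of hydrogen on an aromatic carbon, and the step it produced is a 1.7-fold lower number from compound 1 to compound 2 (0.24 log units; within the scatter). Compound 3 `COc1ccccc1/C=C/C(=O)c1ccc(N)cc1` gives 6300 nM in this assay; the difference between the core of compound 3 and the core of compound 1 is not broken down here.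

Compound 4 `COc1cccc(/C=C/C(=O)c2ccc(N)cc2)c1OC` remains to be measured. Relative to compound 3 the change is methoxy in place of hydrogen on an aromatic carbon, the same kind of change as seen from compound 1 to compound 2, though here the place is ortho to a methoxy group, which the earlier place was not. Because a 1.7-fold lower number from compound 1 to compound 2 (0.24 log units; within the scatter) lay within the scatter, a step of similar size, a 1.4-fold lower number from compound 3 to compound 4 (0.15 log units; within the scatter), is expected from compound 3 to compound 4. Compound 4 is estimated at 4500 nM, expected between 2000 nM and 10000 nM.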

Compound 4, half-maximal inhibitory concentration: 7600 nM
Estimate against measurement, compound 4: 1.7-fold (0.23 log units) below, and the stated range covers the measured number.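

In this assay, methoxy in place of hydrogen on an aromatic carbon gives a 1.2-fold higher number from compound 3 to compound 4 (0.08 log units; within the scatter). Set beside the earlier step, the two cores do not separate: the same change on two cores in this assay, a 1.7-fold lower number (0.24 log units; within the scatter) from compound 1 to compound 2 and a 1.2-fold higher number (0.08 log units; within the scatter) from compound 3 to compound 4, 2.1-fold (0.32 log units) apart, within the scatter of two such steps. On these two cores, neither step exceeds the scatter, so this shows no core dependence, but it does not show that the change has a real effect on either core or that it would behave alike on others.

Each core offers a single pair, and the new methoxy sits ortho to a methoxy group only on the core of compound 3, so place and core cannot be told apart. On these data alone, whether a hydroxyl or a longer alkoxy chain at this place would give a step beyond the scatter stays open.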